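Acetyl Replaces Trifluoromethyl in a Rat Inhibition Series

The source may hold more compounds than are shown below. What is called first, only, known or untested is meant among the compounds shown, and "the series" means these compounds.

Measured so far:
compound 1 `CCOc1ccc(N/N=C2\CCC(C)n3c2ncc(C(=O)O)c3=O)cc1` — 1.6 umol/kg
compound 2 `CC1CC/C(=N\Nc2ccc(C(F)(F)F)cc2)c2ncc(C(=O)O)c(=O)n21` — 38.6 umol/kg

In a functional assay on the whole organism for inhibition, with Rattus norvegicus as the target (a higher number here means that more compound is needed for the effect, a lower number that less compound is needed), compound 2 gives the highest number of the two measured, and only compound 1 is known beside it. Within the data shown here, the one measured step, a 24-fold higher number from compound 1 to compound 2 (1.38 log units; beyond the scatter), showed that the ethoxy compound needed far less than the trifluoromethyl compound. Compound 3 `CC(=O)c1ccc(N/N=C2\CCC(C)n3c2ncc(C(=O)O)c3=O)cc1` carries the change (acetyl in place of trifluoromethyl on an aromatic carbon). Among the measured compounds shown here, no step with acetyl has been measured, so the estimate leans on that single step, expecting a partial return toward compound 1. Compound 3 is expected to give 6 umol/kg (range 1.5 umol/kg to 25 umol/kg), an expected step of a 6.4-fold lower number from compound 2 to compound 3 (0.81 log units; beyond the scatter).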

Compound 3, dose for 50% inhibition: 9.5 umol/kg
The estimate for compound 3 lay 1.6-fold (0.20 log units) below the measured number; the range from low to high includes it.
By their numbers in this assay, from the lowest: compound 1; then compound 3; then compound 2.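

Swapping trifluoromethyl for acetyl on this aromatic carbon lowers the dose needed in this assay (a 4.1-fold lower number from compound 2 to compound 3 (0.61 log units; beyond the scatter)), so the high number of compound 2 is not shared by every group other than ethoxy. Acetyl still falls short of ethoxy (a 5.9-fold higher number from compound 1 to compound 3 (0.77 log units; beyond the scatter)), which leaves compound 1 needing the least of the three. Nothing available explains this order. Going by these compounds, whether an amine or a longer chain such as propoxy on this carbon would match ethoxy stays open, as does whether the same order would hold with changes elsewhere on the shared core.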